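Cyano-bearing chains on the sulfonamide nitrogen

The source may report more compounds than this note shows. Statements on the series, on what has been measured and on what is new or still open speak of the compounds shown alone.

Measured so far in an ADME assay on MDCKII-LE cells (Canis lupus familiaris) for permeability (a higher number here means that the compound crosses the layer faster, a lower number that the compound crosses the layer more slowly), as follows:
- compound 1 `N#Cc1ccc(CN([C@H](CCC(F)(F)F)C(N)=O)S(=O)(=O)c2ccc(Cl)cc2)cc1` gives 19.7 10^-6 cm/s
- compound 2 `N#CCCCCN([C@H](CCC(F)(F)F)C(N)=O)S(=O)(=O)c1ccc(Cl)cc1` gives 24 10^-6 cm/s

Going by the values given here, compound 2 and compound 1, the only two measured compounds, lie within the scatter of each other. Compound 3 `N#C[C@H]1C[C@@H]1CN([C@H](CCC(F)(F)F)C(N)=O)S(=O)(=O)c1ccc(Cl)cc1` carries 2-cyanocyclopropyl in place of 3-cyanopropyl on a saturated chain carbon bound to a sulfonamide nitrogen. Among the compounds with values here, the one measured step, a 1.2-fold higher number from compound 1 to compound 2 (0.09 log units; within the scatter), changes the group at this same place, but it involves a different pair of groups and so gives only indirect guidance. With that single step as a guide, no step beyond the scatter is expected in this assay for compound 3. The estimate means a 1.1-fold lower number from compound 2 to compound 3 (0.06 log units; within the scatter) as the expected step. Compound 3 is estimated at 21 10^-6 cm/s (11 10^-6 cm/s to 38 10^-6 cm/s).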

Compound 3, apparent permeability: 21.5 10^-6 cm/s
Beside the measured number, compound 3's estimate is 1.0-fold (0.01 log units) below it, within the range that was stated.
By their numbers in this assay, from the lowest: compounds 1, 3 and 2 (each within the scatter of the next).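

In this assay, 2-cyanocyclopropyl in place of 3-cyanopropyl gives a 1.1-fold lower number from compound 2 to compound 3 (0.05 log units; within the scatter), and in place of 4-cyanophenyl it gives a 1.1-fold higher number from compound 1 to compound 3 (0.04 log units; within the scatter). The three groups on this saturated chain carbon bound to a sulfonamide nitrogen therefore all lie within the scatter, now including one with a three-membered ring and 2 defined stereocentres. No supporting data bear on this result.

Still open, on these data alone, is whether a carboxylic acid, an amine or a longer chain at this place would give a step beyond the scatter. As far as these compounds go, the other stereoisomers of 2-cyanocyclopropyl also remain open.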